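A methyl group leaves compound 2

The compounds below may be only part of what the source reports. "The series", "measured", "known", "first", "only" and "open" are said of these compounds alone.

Compound 1 `COc1ccnc(C[S+]([O-])c2nc3cc(OC(F)F)ccc3[nH]2)c1` with 0.8 h
Compound 2 `COc1c(C)cnc(C[S+]([O-])c2nc3cc(OC(F)F)ccc3[nH]2)c1C` with 1.9 h

Compound 2 stands highest of the two in an ADME assay, at pH 5 (on this read-out lower numbers stand for a shorter-lived compound and higher numbers for a longer-lived compound), at 1.9 h, while compound 1 lies lower at 0.8 h, a gap beyond the usual scatter. For the measured compounds named here, no pair of measured compounds differs in one place only, so no measured step guides the next comparison.

The next compound is compound 3 `COc1ccnc(C[S+]([O-])c2nc3cc(OC(F)F)ccc3[nH]2)c1C`, which has not yet been measured. Its change from compound 2 is hydrogen in place of methyl on an aromatic carbon.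

In this assay a small step toward a shorter-lived compound is expected, probably within the scatter. Going by the values given here, the only guide is that compound 1 at 0.8 h sits lower than compound 2, so compound 3 is expected to fall in or near the span of those two values. The estimated step is a 1.6-fold lower number from compound 2 to compound 3 (0.20 log units; within the scatter) in this read-out. Compound 3 is estimated at 1.2 h with an expected range from 0.7 h to 2.1 h for its half-life.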

Compound 3, half-life: 0.17 h
Compound 3: the middle estimate sits 7.1-fold (0.85 log units) above what was measured, and the stated range ends above it.
By their numbers in this assay, from the lowest: compound 3; then compound 1; then compound 2.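

With the methyl group in place, on the aromatic carbon ortho to a methoxy group and para to a large group, compound 2 is the longest-lived of the three in this assay; its removal gives an 11-fold lower number from compound 2 to compound 3 (1.05 log units; beyond the scatter), so the loss of this one carbon is a large change and this position clearly matters on this read-out. For the compounds shown here, the other ring methyl, the one kept in compound 3, goes the opposite way when it is the only methyl on that ring, giving a 4.7-fold lower number from compound 1 to compound 3 (0.67 log units; beyond the scatter). The same kind of change, methyl for hydrogen on an aromatic carbon, therefore goes with a longer half-life at the place lost from compound 2 and with a shorter half-life at the place kept in compound 3, which shows that the effect of a methyl group here cannot be read from a single position, though this rests on just these three compounds.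

Nothing available accounts for these shifts. As far as these compounds go, it remains open whether an ethyl group, a chlorine atom or a methoxy group at this position would keep the longer half-life of compound 2, or whether the methyl group itself is needed.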